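This account rests on a few compounds, and the source may have more. Where it says the series, first, only, none or still open, it means among the compounds named here.

Compound 1 `CNC1=Nc2ccc(Cl)cc2C(C)(C)C1` gives 91.9% in a functional assay on MDA-MB-231 cells (Homo sapiens) for cytotoxicity, read by MTT assay, with a stated time of 72 h, tested at 1 uM, in the absence of a further agent; on this read-out higher numbers stand for a weaker effect at the one concentration tested and lower numbers for a stronger effect; compound 2 `CC1(C)CC(NCCCCO)=Nc2ccc(Cl)cc21` gives 87.6% in that assay, with a number 4.3 percentage points lower from compound 1 to compound 2 (within the scatter). Compound 3 `CN(C)CCCNC1=Nc2ccc(Cl)cc2C(C)(C)C1` gives 54.1% in that assay, the lowest of the three numbers, with a number 37.8 percentage points lower from compound 1 to compound 3 (beyond the scatter) and a number 33.5 percentage points lower from compound 2 to compound 3 (beyond the scatter), so the two tertiary-amine steps are the only large ones in the set and both point downward.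

Compound 4 `CCN(CC)CCCNC1=Nc2ccc(Cl)cc2C(C)(C)C1` differs from compound 3 in one place: diethylamino in place of dimethylamino on a saturated chain carbon, three bonds along the chain from an amine nitrogen. Among the compounds with values here, no measured step bears directly on this exchange: every step in the set either adds a chain to the amine nitrogen or swaps hydroxymethyl for dimethylamino, so the effect of lengthening the two alkyl groups on that nitrogen is not covered. The chain bearing the basic nitrogen is kept, and compound 3 shows where that chain puts the number in that assay; the expectation is therefore a step of a number 6.1 percentage points lower from compound 3 to compound 4 (within the scatter), within the scatter. Compound 4 is estimated at 48% in that assay, with a range from 30% to 68%.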

Compound 4, a percentage reported as activity, at one concentration (the size of the read-out at that concentration, not a potency): 53.3%
The estimate for compound 4 lay 5.3 percentage points below the measured number; measured number inside the range.
By their numbers in this assay, from the lowest: compounds 4 and 3 (each within the scatter of the next); then compounds 2 and 1 (each within the scatter of the next).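

In this assay, diethylamino in place of dimethylamino at this place, on a saturated chain carbon, three bonds along the chain from an amine nitrogen, gives a number 0.8 percentage points lower from compound 3 to compound 4 (within the scatter), so going from 3 to 5 heavy atoms in this group does not move the number beyond the scatter. The large steps seen with dimethylamino recur with diethylamino, with a number 34.3 percentage points lower from compound 2 to compound 4 (beyond the scatter) and a number 38.6 percentage points lower from compound 1 to compound 4 (beyond the scatter). Among the compounds shown, the two alkyl groups on this nitrogen can therefore be either methyl or ethyl without separating compound 3 and compound 4, and no available data address what lies behind these numbers.

Still open, on these data alone, is whether a piperidine or morpholine in place of diethylamino, or a primary amine at the same place, stays with compound 3 and compound 4. Within the data shown here, a longer chain carrying the diethylamino group is equally open, and the single tested concentration gives no potency for any compound.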